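Adding a propyl group to the indole nitrogen of compound 1

The source may hold more compounds than are shown below. What is called first, only, known or untested is meant among the compounds shown, and "the series" means these compounds.

Compound 1, `COc1cc(C(=O)NS(=O)(=O)c2ccccc2)ccc1Cc1c[nH]c2ccc(NC(=O)OC3CCCC3)cc12`, is the most potent of the three measured compounds in an assay on isolated protein (Cavia porcellus) with cysteinyl leukotriene receptor (Homo sapiens) as the target (a higher number here means a more potent compound, by a factor of ten per unit of this negative logarithm, a lower number a less potent compound), where compound 1 gives 9.8. Compound 2, `COc1cc(C(=O)O)ccc1Cc1c[nH]c2ccc(NC(=O)OC3CCCC3)cc12`, gives 7.32, and the step of a number 2.48 log units lower from compound 1 to compound 2 (beyond the scatter) shows how much is lost when the carbonyl carbon carries a hydroxy instead of a (phenylsulfonyl)amino group. Compound 3, `COc1cc(C(=O)O)ccc1Cc1cn(C2CCCC2)c2ccc(NC(=O)OC3CCCC3)cc12`, gives 7.67, a step of a number 0.35 log units higher from compound 2 to compound 3 (beyond the scatter).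

Compound 4, `CCCn1cc(Cc2ccc(C(=O)NS(=O)(=O)c3ccccc3)cc2OC)c2cc(NC(=O)OC3CCCC3)ccc21`, differs from compound 1 in one place: propyl in place of hydrogen on an aromatic nitrogen. Among the measured compounds shown here, the only measured step that bears on this change is the one from compound 2 to compound 3, which put a cyclopentyl on the same aromatic nitrogen and gave a number 0.35 log units higher from compound 2 to compound 3 (beyond the scatter), a modest gain. A propyl is a smaller group at the same place, so in this assay a step of about a number 0.10 log units higher from compound 1 to compound 4 (within the scatter) is expected, either none beyond the scatter or a slight rise. Compound 4 is therefore estimated at 9.9, with a range from 9.3 to 10.5.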

Compound 4, negative logarithm of the antagonist equilibrium constant: 8.44
Estimate against measurement, compound 4: 1.46 log units above; the whole stated range lies above it.
By their numbers in this assay, from the lowest: compound 2; then compound 3; then compound 4; then compound 1.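

In this assay, putting propyl in place of hydrogen on the aromatic nitrogen of compound 1 gives a number 1.36 log units lower from compound 1 to compound 4 (beyond the scatter), which shows that this nitrogen is far from indifferent to substitution when the carbonyl carbon carries the (phenylsulfonyl)amino group. Among the compounds shown here, the only earlier change at this nitrogen, a number 0.35 log units higher from compound 2 to compound 3 (beyond the scatter), went the other way, but it involved a different group and a compound with hydroxy on the carbonyl carbon, so a gain seen in one setting did not carry over to the other. Nothing available accounts for the drop.

From the compounds shown here alone, it remains open whether a methyl or a longer chain such as butyl on this nitrogen of compound 1 would cost as much as propyl. Also open, going by these compounds, is how cyclopentyl would behave there, which would separate the effect of the entering group from that of the group on the carbonyl carbon.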